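The compounds below may be only part of what the source reports. "The series", "measured", "known", "first", "only" and "open" are said of these compounds alone.

Measured compounds in a functional assay on B16-F10 cells (Mus musculus) for inhibition, read by MTT assay, with a stated time of 72 h; on this read-out lower numbers stand for stronger inhibition and higher numbers for weaker inhibition:
Compound 1, `CC(C)c1ccc(Nc2nc(SCc3cn(CC(=O)NC(=O)Nc4ccccn4)nn3)nc(-c3ccc(C(C)C)cc3)c2C#N)cc1`: 4380 nM
Compound 2, `COc1cc(-c2nc(SCc3cn(CC(=O)NC(=O)Nc4ccccn4)nn3)nc(Nc3ccc(C(C)C)cc3)c2C#N)cc(OC)c1OC`: 1210 nM
Compound 3, `CC(C)c1ccc(Nc2nc(SCc3cn(CC(=O)NC(=O)Nc4ccccn4)nn3)nc(-c3ccc(Br)cc3)c2C#N)cc1`: 42 nM

Compound 3 stands lowest of the three numbers in this assay. Its nearest neighbour is compound 2, which differs by a 29-fold lower number from compound 2 to compound 3 (1.46 log units; beyond the scatter); the furthest is compound 1, which differs by a 100-fold lower number from compound 1 to compound 3 (2.02 log units; beyond the scatter). Both of these steps lie well beyond the scatter, so compound 3 is the most potent of the measured set. The remaining step, a 3.6-fold lower number from compound 1 to compound 2 (0.56 log units; beyond the scatter), is modest by comparison.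

Compound 4, `CC(C)c1ccc(Nc2nc(SCc3cn(CC(=O)NC(=O)Nc4ccccn4)nn3)nc(-c3ccc(Cl)cc3)c2C#N)cc1`, has not yet been measured in this assay. It differs from compound 3 in one place: chloro in place of bromo on an aromatic carbon, on an aromatic carbon of a six-membered aromatic ring of carbon only. Among the compounds with values here, only one measured step touches this position, namely a 100-fold lower number from compound 1 to compound 3 (2.02 log units; beyond the scatter), where bromo in place of isopropyl produced a large gain. No measured pair compares bromo with chloro, so the size of that swap is not shown by the data. Since both are single-atom halogens occupying the same place, a small step is expected, at most near the edge of the scatter, and if anything toward a slightly higher number. The estimated step in this assay is a 1.7-fold higher number from compound 3 to compound 4 (0.22 log units; within the scatter). Compound 4 is therefore expected to give roughly 70 nM in this assay, with a likely range from 25 nM to 200 nM.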

Compound 4, half-maximal inhibitory concentration: 1590 nM
For compound 4 the middle estimate is 23-fold (1.36 log units) below the measured one; the whole stated range lies below it.
By their numbers in this assay, from the lowest: compound 3; then compounds 2 and 4 (each within the scatter of the next); then compound 1.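

In this assay, this place does not treat the two halogens alike: a 38-fold higher number from compound 3 to compound 4 (1.58 log units; beyond the scatter), although the swap exchanges one halogen atom for another with no change in the counted donors or acceptors, so the large gain of bromo over isopropyl is not shared in full by chloro. Chloro keeps only a modest part of that gain, with a 2.8-fold lower number from compound 1 to compound 4 (0.44 log units; beyond the scatter), and the 4-chlorophenyl compound stays within the scatter of the 3,4,5-trimethoxyphenyl compound, with a 1.3-fold higher number from compound 2 to compound 4 (0.12 log units; within the scatter), which leaves compound 3 alone as the most potent of the four. Nothing among the available data explains why bromo and chloro lie so far apart here.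

Open, as far as these compounds go, is whether iodo, fluoro, methyl or trifluoromethyl at this same place would fall nearer to bromo or to chloro, and so whether bromo is a lone exception or part of a wider trend. Also open, from the compounds shown here alone, is whether the gap between bromo and chloro would persist with another group elsewhere on the shared core, or in cells other than those of this assay.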